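The compounds below may be only part of what the source reports. "The series", "measured", "known", "first", "only" and "open" are said of these compounds alone.

In a functional assay on HT-29 cells (Homo sapiens) for antiproliferative activity, read by MTT assay, with a stated time of 48 h (a higher number here means a weaker inhibitor, a lower number a stronger inhibitor), compound 1 `O=C(/C=C\Nc1ccc(Cl)cc1)c1cn(-c2ccccc2)nc1-c1ccc(F)cc1` gives 4600 nM. Compound 2 `COc1ccc(N/C=C\C(=O)c2cn(-c3ccccc3)nc2-c2ccc(F)cc2)cc1` carries a single change, (methoxy in place of chloro on an aromatic carbon), and in this assay compound 2 gives 3200 nM. The step of a 1.4-fold lower number from compound 1 to compound 2 (0.16 log units; within the scatter) is small, so the two compounds cannot be told apart by this measurement.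

Compound 3 `O=C(/C=C\Nc1ccc(F)cc1)c1cn(-c2ccccc2)nc1-c1ccc(Cl)cc1` has the same atoms as compound 1, joined differently; the difference between the two cores is not broken down here. In this assay compound 3 reaches only > 50000 nM, which is a limit of the assay rather than a number. This is the same limit as the limit of > 50000 nM in this assay, at which 1 of the 3 values shown sits.

Compound 4 `COc1ccc(-c2nn(-c3ccccc3)cc2C(=O)/C=C\Nc2ccc(F)cc2)cc1` has not yet been measured. It differs from compound 3 by methoxy in place of chloro on an aromatic carbon, and the place of the change reads the same as in the step from compound 1 to compound 2, though the wider reading of the earlier change also took in (4-chlorophenyl)amino to (4-methoxyphenyl)amino, so the two changes sit on different rings of their cores. Since the same change on compound 1 gave the step of a 1.4-fold lower number from compound 1 to compound 2 (0.16 log units; within the scatter), the step that the limit leaves unreadable from compound 3 to compound 4 expected from compound 3 to compound 4 in this assay is equally small, and, since compound 3 sits at a limit, compound 4 is expected to stay near that limit too. The estimate for compound 4 in this assay is 60000 nM, within a range of 20000 nM to 200000 nM.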

Compound 4, half-maximal inhibitory concentration: 7650 nM
Beside the measured number, compound 4's estimate is 7.8-fold (0.89 log units) above it; the whole stated range lies above it.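

In this assay, putting methoxy in place of chloro on the 4-chlorophenyl ring gives an at least 6.5-fold lower number from compound 3 to compound 4 (0.81 log units; beyond the scatter), a real change in the measured number, whereas the same swap on the other ring gave a 1.4-fold lower number from compound 1 to compound 2 (0.16 log units; within the scatter). Set side by side, the two results show that this change does not carry over with the same size from one core to the other, so the step seen on one core would not have predicted the step on the other: the same change on two cores in this assay, a 1.4-fold lower number (0.16 log units; within the scatter) from compound 1 to compound 2 and an at least 6.5-fold lower number (0.81 log units; beyond the scatter) from compound 3 to compound 4, at least 4.5-fold (0.65 log units) apart, beyond the scatter of two such steps. Compound 3 reads > 50000 nM, which is a limit of the assay and not a number, so the size of its step is bounded on one side only, and two pairs of compounds cannot show why the change behaves differently on the two cores.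

The compounds shown leave open whether another group in the same place, such as an amine or a carboxylic acid, would bring the number down as methoxy does in compound 4 or would stay near the limit. They also leave open whether a nitrile or a hydroxyl group in place of the chloro would separate the two cores in the same way.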